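The source may hold more compounds than are shown below. What is called first, only, known or untested is meant among the compounds shown, and "the series" means these compounds.

Measured so far:
- compound 1, `COc1cccc2c1OCN(c1ccc3oc(-c4ccccc4)cc(=O)c3c1)C2`, with 91.9% in a functional assay on MCF7 cells (Homo sapiens) for inhibition, read by MTT assay, with a stated time of 48 h, tested at 60 ug/mL; on this read-out higher numbers stand for more inhibition of growth at the one concentration tested and lower numbers for less inhibition of growth
- compound 2, `O=c1cc(-c2ccccc2)oc2cc(N3COc4c(cccc4[N+](=O)[O-])C3)ccc12`, with 15.7% in this assay

Of these two numbers compound 1 stands highest; compound 2 lies far lower, and that gap is beyond the usual scatter. Compound 3, `O=c1cc(-c2ccccc2)oc2ccc(N3COc4ccccc4C3)cc12`, has not yet been tested. It differs from compound 1 in one spot: hydrogen in place of methoxy on an aromatic carbon. Going by the values given here, since no step of this kind has been measured here, the direction is open, though the weak result of compound 2 shows that this part of the shared core can matter. A moderate drop is expected, a number 21.9 percentage points lower from compound 1 to compound 3 (beyond the scatter), with wide uncertainty. Compound 3 is therefore estimated at 70%, within 40% to 95%.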

Compound 3, percent growth inhibition at one concentration: 92.7%
Estimate against measurement, compound 3: 22.7 percentage points below; measured number inside the range.
By their numbers in this assay, from the lowest: compound 2; then compounds 1 and 3 (each within the scatter of the next).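

In this assay the change to hydrogen in place of methoxy on this aromatic carbon gives a number 0.8 percentage points higher from compound 1 to compound 3 (within the scatter) and so leaves the inhibition of growth at this one concentration in place. The methoxy group is therefore not needed here for the high read-out, and a bare aromatic carbon serves as well. No measured evidence explains this result.

As far as these compounds go, how an amine, a carboxylic acid or a longer chain such as butoxy would fare on this carbon stays open. A single concentration also cannot show whether compound 1 and compound 3 would still match at lower doses.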